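This account rests on a few compounds, and the source may have more. Where it says the series, first, only, none or still open, it means among the compounds named here.

In an assay on HEK293 cells for negative allosteric modulation of metabotropic glutamate receptor 5 (Homo sapiens), read by FLIPR (on this read-out higher numbers stand for weaker inhibition and lower numbers for stronger inhibition), compound 3 `O=C(c1ccccc1F)N1CC(c2nc(-c3cccc(Cl)c3)no2)C1` gives 670 nM, the lowest of the two numbers recorded here. Compound 1 `O=C(C1CCC1)N1CC(c2nc(-c3cccc(Cl)c3)no2)C1` gives 1500 nM, and the step of a 2.2-fold lower number from compound 1 to compound 3 (0.35 log units; beyond the scatter) separates the two. Compound 2 `O=C(N1CCCCCC1)N1CC(c2nc(-c3cccc(Cl)c3)no2)C1` is recorded in this assay only as a limit, > 10000 nM (the limit of > 10000 nM in this assay, at which 1 of the 3 values shown sits).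

Compound 4 `CC1CN(C(=O)N2CC(c3nc(-c4cccc(Cl)c4)no3)C2)CC(C)O1` differs from compound 3 in one place: 2,6-dimethylmorpholin-4-yl in place of 2-fluorophenyl on a carbonyl carbon. Going by the values given here, two measured steps bear on this exchange. Replacing cyclobutyl with azepan-1-yl gave an at least 6.6-fold higher number from compound 1 to compound 2 (0.82 log units; beyond the scatter), and replacing azepan-1-yl with 2-fluorophenyl gave an at least 14-fold lower number from compound 2 to compound 3 (1.17 log units; beyond the scatter). In both of these the compound carrying azepan-1-yl on the carbonyl carbon sat at the limit of this assay, and 2,6-dimethylmorpholin-4-yl, the group entering compound 4, is like azepan-1-yl a non-aromatic ring joined to the carbonyl carbon through its nitrogen. The step from the aromatic ring of compound 3 to this ring is therefore expected to be large and upward, on the order of a 12-fold higher number from compound 3 to compound 4 (1.08 log units; beyond the scatter). Compound 4 is estimated at 8000 nM, with a range from 2500 nM to 30000 nM, and with a substantial chance that this assay again reports only a limit.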

Compound 4, half-maximal inhibitory concentration: 990 nM
Estimate against measurement, compound 4: 8.1-fold (0.91 log units) above, outside the stated range (below it).
By their numbers in this assay, from the lowest: compounds 3, 4 and 1 (each within the scatter of the next, the first and the last beyond it). At a limit, above all of these: compound 2.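

In this assay, a non-aromatic ring joined to the carbonyl carbon through its nitrogen proves compatible with a measurable read-out: 2,6-dimethylmorpholin-4-yl in place of 2-fluorophenyl gives a 1.5-fold higher number from compound 3 to compound 4 (0.17 log units; within the scatter) and in place of cyclobutyl gives a 1.5-fold lower number from compound 1 to compound 4 (0.18 log units; within the scatter) in the same series. Until now, azepan-1-yl was the only ring of this kind at this position, so its loss could have applied to all such rings, but the two now part, with an at least 10-fold lower number from compound 2 to compound 4 (1.00 log units; beyond the scatter) on this same carbonyl carbon, and compound 2 therefore goes against any rule that such rings fail here. The figure for compound 2 remains a limit and not a number: the limit of > 10000 nM in this assay, at which 1 of the 4 values shown sits.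

Going by these compounds, what separates compound 4 from compound 2 stays open, since the two rings differ in size, in the ring oxygen and in the two methyl groups at once. Whether morpholin-4-yl without those methyl groups, or piperidin-1-yl, would sit with compound 4 or with compound 2 cannot be told from the compounds shown, all of which also share the same core.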